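This account rests on a few compounds, and the source may have more. Where it says the series, first, only, none or still open, it means among the compounds named here.

Measured compounds:
compound 1 `COc1cc(C)cc(-c2c(-c3ccnc(-c4ccc(C(C)=O)cc4)c3)cnn2CC#N)c1`, 5840 nM
compound 2 `COc1cc(C)cc(-c2nn(CC#N)cc2-c2ccc(-c3cccc(C(C)=O)c3)nc2)c1`, 2630 nM
compound 3 `Cc1cc(O)cc(-c2nn(CC#N)cc2-c2ccnc(-c3ccc(N(C)C)cc3)c2)c1`, 2180 nM

All three were run in a functional assay on SF-295 cells (Homo sapiens) for inhibition, read by sulforhodamine B assay, with a stated time of 48 h; a higher number here means a weaker inhibitor of growth, a lower number a stronger inhibitor of growth. Compound 1 stands with the highest number of the three: compound 2 sits lower by a step beyond the scatter, and compound 3 lower still, also beyond the scatter. On these numbers compound 1 is thus the weakest inhibitor of growth of the set. Going by the values given here, no two of the three differ in only one place, so no single-change step between measured compounds is available.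

Compound 4 `COc1cc(C)cc(-c2c(-c3ccnc(-c4ccc(N(C)C)cc4)c3)cnn2CC#N)c1` is not yet measured. Against compound 1 the change is dimethylamino in place of acetyl on an aromatic carbon, in words dimethylamino in place of acetyl on an aromatic carbon. Compound 3 carries the same dimethylamino group on a differently substituted core and gives 2180 nM, which is only indirect guidance, as the cores do not match.

Taking the picture as a whole, the step of a 1.8-fold lower number from compound 1 to compound 4 (0.25 log units; within the scatter) is expected to run toward a lower number, of moderate size and probably beyond the scatter. Compound 4 is therefore estimated at 3300 nM, with a range from 1200 nM to 9000 nM in this assay.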

Compound 4, concentration for 50% growth inhibition: 52.9 nM
Compound 4: the middle estimate sits 62-fold (1.80 log units) above what was measured; measured number below the stated range.
By their numbers in this assay, from the lowest: compound 4; then compounds 3 and 2 (each within the scatter of the next); then compound 1.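

In this assay, dimethylamino in place of acetyl on this aromatic carbon, para to a large group, gives a 110-fold lower number from compound 1 to compound 4 (2.04 log units; beyond the scatter), a large step and the only single-change comparison among the compounds shown. Going by these compounds alone, the earlier compounds offered no such step, so this is the first direct sign that the group at this position alone can strongly shift growth inhibition while the rest of the core of compound 1 stays unchanged, and the shift appears even though the two groups have the same counts of heavy atoms, hydrogen-bond donors and hydrogen-bond acceptors. No measurement available here bears on why the 4-acetylphenyl to 4-(dimethylamino)phenyl exchange has so large an effect.

On these data alone, it remains open whether this result is specific to dimethylamino, or whether a primary amine, a morpholine ring or a pyrrolidine ring on the same carbon would give a similar number. Also open, as far as these compounds go, is whether an exchange of acetyl for dimethylamino would produce a step of similar size on the core of compound 2.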